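This account rests on a few compounds, and the source may have more. Where it says the series, first, only, none or still open, it means among the compounds named here.

Measured so far in an ADME assay on HEK293 cells (Homo sapiens) for inhibition, with a stated time of 72 h; on this read-out lower numbers stand for an effect already at smaller amounts and higher numbers for an effect only at larger amounts of compound:
- compound 1 `C=C(C)C(=O)Nc1cccc(-c2nc3ccccc3s2)c1`: > 25000 nM
- compound 2 `O=C(O)/C=C/C(=O)Nc1cccc(-c2nc3ccccc3s2)c1`: > 25000 nM
- compound 3 `CN(C)CCC(=O)Nc1cccc(-c2nc3ccccc3s2)c1`: > 25000 nM

Each of these three values is a limit of the assay and not a number. Compound 3 therefore stands only at the limit of > 25000 nM in this assay, at which 3 of the 3 values shown sit, in this assay, and the same holds for compound 1 and for compound 2. The steps a step that the two limits leave unreadable from compound 1 to compound 2, a step that the two limits leave unreadable from compound 1 to compound 3 and a step that the two limits leave unreadable from compound 2 to compound 3 cannot be read for size from two limits.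

Compound 4 `O=C(CCl)Nc1cccc(-c2nc3ccccc3s2)c1` is the next one: chloro in place of (dimethylamino)methyl on a saturated chain carbon bound to a carbonyl carbon. Among the measured compounds shown here, no measured step bears on this change, so there is no ground to expect movement in either direction; the estimated step of an at least 1.2-fold lower number from compound 3 to compound 4 (0.09 log units; that floor lies within the scatter) is set near nothing. The expected value for compound 4 is 20000 nM, with a range from 3000 nM to 60000 nM.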

Compound 4, half-maximal effective concentration: 10000 nM
The estimate for compound 4 lay 2.0-fold (0.30 log units) above the measured number; the range from low to high includes it.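

Of the four compounds in this assay, only compound 4, with chloromethyl on the carbonyl carbon, gives a number, so the group at this place can change the read-out on the shared core. The series shows an at least 2.5-fold lower number from compound 3 to compound 4 (0.39 log units; beyond the scatter), an at least 2.5-fold lower number from compound 2 to compound 4 (0.39 log units; beyond the scatter) and an at least 2.5-fold lower number from compound 1 to compound 4 (0.39 log units; beyond the scatter). The other three values are limits of the assay: the limit of > 25000 nM in this assay, at which 3 of the 4 values shown sit.

The steps among compounds 1, 2 and 3 cannot be read. Going by these compounds, whether the chlorine itself matters stays open, as a plain methyl, a hydroxymethyl or a bromomethyl on the same carbonyl carbon would show.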